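The compounds below may be only part of what the source reports. "The series", "measured", "known", "first", "only" and "open" are said of these compounds alone.

Compound 1 `COc1cc2c(Nc3nc4ccc(C(=O)Nc5c(C)cccc5C)cc4s3)ncnc2cc1OCCCN1CCCCC1C`: > 100000 nM
Compound 2 `COc1cc2c(Nc3nc4ccc(C(=O)Nc5c(C)cc(C)cc5C)cc4s3)ncnc2cc1OCCCN1CCCCC1C`: 5600 nM

Among the measured compounds shown here, in a functional assay on HCT-116 cells (Homo sapiens) for cytotoxicity, read by WST assay, with a stated time of 72 h (on this read-out lower numbers stand for stronger inhibition and higher numbers for weaker inhibition), compound 2 gives 5600 nM, the only actual number so far. Compound 1 gives > 100000 nM, which is a limit of the assay and not a number. Compound 3 `COc1cc2c(Nc3nc4ccc(C(=O)Nc5c(C)cc(C)cc5C)cc4s3)ncnc2cc1OCCCN1CCCCC1` changes compound 2 in one place: hydrogen in place of methyl on a saturated ring carbon. This puts hydrogen in place of methyl on a saturated ring carbon, turning 2-methylpiperidin-1-yl into piperidin-1-yl.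

For the measured compounds named here, the one measured step, an at least 17-fold lower number from compound 1 to compound 2 (1.25 log units; beyond the scatter), was large, but it concerns methyl on an aromatic carbon, not this ring. Going by these compounds, it also starts from the limit of > 100000 nM in this assay, at which 1 of the 2 values shown sits, so its true size is unknown. It shows only that one methyl can matter in this pair. Going by the values given here, no step has been measured at the saturated ring carbon, so the best anchor is compound 2 at 5600 nM, and no step beyond the scatter is expected, in either direction. The expected change is a 1.1-fold lower number from compound 2 to compound 3 (0.05 log units; within the scatter). Compound 3 is estimated at 5000 nM, with an expected range of 1200 nM to 20000 nM.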

Compound 3, half-maximal inhibitory concentration: 16900 nM
Compound 3: the middle estimate sits 3.4-fold (0.53 log units) below what was measured; low and high end bracket the measured number.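

Removing the methyl from the saturated ring carbon next to the ring nitrogen, which turns 2-methylpiperidin-1-yl into piperidin-1-yl, gives a 3.0-fold higher number from compound 2 to compound 3 (0.48 log units; beyond the scatter) in this assay. This modest step shows that this far end of the molecule is not silent, and that here the methyl goes with stronger inhibition, the same direction as the methyl on the aromatic carbon in the earlier pair. Compound 1 stands at a limit and not at a number, and so the two methyl steps cannot be ranked by size because the earlier one has no known size: the limit of > 100000 nM in this assay, at which 1 of the 3 values shown sits.

Going by these compounds, whether a larger group on this carbon, such as ethyl, would lower the number further stays open. So does the effect of replacing the piperidine ring with morpholin-4-yl, or of an amine without a ring.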